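From compound 3 to compound 4: one more swap

The compounds below may be only part of what the source reports. "The series", "measured", "known", "first", "only" and "open" are said of these compounds alone.

Compound 1 `C=CS(=O)(=O)N1CCN(c2ncnc3sc(-c4cccc5ccccc45)cc23)CC1`: 23700 nM
Compound 2 `C=CS(=O)(=O)N1CCN(c2ncnc3sc(-c4ccc(OC)nc4)cc23)CC1`: 9270 nM
Compound 3 `C=CS(=O)(=O)N1CCN(c2ncnc3sc(-c4ccc(F)nc4)cc23)CC1`: 16000 nM

All three share one core and were tested in a functional assay on MDA-MB-231 cells (Homo sapiens) for antiproliferative activity, read by MTT assay, with a stated time of 48 h; on this read-out higher numbers stand for weaker inhibition and lower numbers for stronger inhibition. Compound 3 cannot be separated from either other compound: a 1.5-fold lower number from compound 1 to compound 3 (0.17 log units; within the scatter) and a 1.7-fold higher number from compound 2 to compound 3 (0.24 log units; within the scatter) both stay within the scatter. Compound 4 `C=CS(=O)(=O)N1CCN(c2ncnc3sc(-c4cc(Br)cnc4F)cc23)CC1` carries 5-bromo-2-fluoropyridin-3-yl in place of 6-fluoropyridin-3-yl, on the aromatic carbon next to the ring sulfur (5-bromo-2-fluoropyridin-3-yl in place of 6-fluoropyridin-3-yl on an aromatic carbon). Going by the values given here, no measured step adds a bromine. The closest guides are the swaps at this same carbon, and the largest of them, a 2.6-fold lower number from compound 1 to compound 2 (0.41 log units; beyond the scatter), was only modest. A step beyond the scatter is therefore not expected in this assay, and no direction is favoured. The estimated step is a 1.1-fold lower number from compound 3 to compound 4 (0.06 log units; within the scatter). For compound 4 the expected value is 14000 nM, with an estimated range from 6000 nM to 30000 nM.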

Compound 4, half-maximal inhibitory concentration: 24100 nM
Estimate against measurement, compound 4: 1.7-fold (0.24 log units) below, and the stated range covers the measured number.
By their numbers in this assay, from the lowest: compounds 2, 3, 1 and 4 (each within the scatter of the next, the first and the last beyond it).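

In this assay, going by these compounds alone, the first bromine-bearing group at this position, 5-bromo-2-fluoropyridin-3-yl, cannot be separated from 6-fluoropyridin-3-yl (a 1.5-fold higher number from compound 3 to compound 4 (0.18 log units; within the scatter)) or from the much larger naphthalen-1-yl (a 1.0-fold higher number from compound 1 to compound 4 (0.01 log units; within the scatter)). Only 6-methoxypyridin-3-yl stands apart from it, and modestly (a 2.6-fold higher number from compound 2 to compound 4 (0.41 log units; beyond the scatter)). No supporting data offer an explanation for that gap. Still open, from the compounds shown here alone, is whether an amine or a carboxylic acid on this aromatic carbon would give a much lower number, and what bromine does without the fluorine changing place.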